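From furan-3-yl to thiophen-2-yl at the assay limit

The source may report more compounds than this note shows. Statements on the series, on what has been measured and on what is new or still open speak of the compounds shown alone.

In a functional assay on HeLa S3 cells (Homo sapiens) for antiproliferative activity, read by XTT assay, with a stated time of 72 h (on this read-out lower numbers stand for stronger inhibition and higher numbers for weaker inhibition), compound 1 (`Nc1nc(N)c2c(-c3cccs3)cn([C@@H]3O[C@H](CO)[C@@H](O)[C@H]3O)c2n1`) gives > 20000 nM as its reading, which is a limit of the assay and not a number. In this assay compound 2 (`COc1nc(N)nc2c1c(-c1ccoc1)cn2[C@@H]1O[C@H](CO)[C@@H](O)[C@H]1O`) gives > 20000 nM as its reading, likewise only a limit. The two compounds therefore stand at one place on the scale (the limit of > 20000 nM in this assay, at which 2 of the 2 values shown sit), and no order can be drawn between them. Compound 3 (`COc1nc(N)nc2c1c(-c1cccs1)cn2[C@@H]1O[C@H](CO)[C@@H](O)[C@H]1O`) differs from compound 2 in one place (thiophen-2-yl in place of furan-3-yl on an aromatic carbon), with thiophen-2-yl in place of furan-3-yl on an aromatic carbon. Compound 1 also carries thiophen-2-yl, and its reading of > 20000 nM is again a limit. For the measured compounds named here, no measured step is available, so no change beyond the scatter is expected in this assay and the estimated step is a number no higher from compound 2 to compound 3 (the limit leaves the size open) in size. For compound 3 the expected value is 20000 nM within an estimated range of 5000 nM to 40000 nM and a reading at the limit is the likeliest outcome.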

Compound 3, half-maximal inhibitory concentration: > 20000 nM
Compound 3 ended at the assay's limit (the forecaster's own chance of this, stated with the estimate: 75%); the middle value sits exactly at the limit.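

Compound 3 reads only as a limit, as do compound 1 and compound 2, so no step among them can be read: the limit of > 20000 nM in this assay, at which 3 of the 3 values shown sit.

As far as these compounds go, whether thiophen-2-yl in place of furan-3-yl, or methoxy in place of amino, changes the reading in this assay at all stays open.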